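The source may report more compounds than this note shows. Statements on the series, on what has been measured and on what is new or still open speak of the compounds shown alone.

Compound 1 `O=c1c(OCc2ccccc2Cl)c(-c2ccccc2)oc2cc(O)cc(O)c12`: > 100000 nM
Compound 2 `O=c1c(OCc2ccccc2[N+](=O)[O-])c(-c2ccccc2)oc2cc(O)cc(O)c12`: 51000 nM

In an ADME assay on Huh-5-2 cells (Homo sapiens) for cytotoxicity, read by WST assay, with a stated time of 3 days (on this read-out lower numbers stand for higher toxicity in this test and higher numbers for lower toxicity in this test), compound 1 reaches only a limit, > 100000 nM, so its true number is not known (the limit of > 100000 nM in this assay, at which 1 of the 2 values shown sits). Compound 2 gives 51000 nM. For the measured compounds named here, the one measured step, an at least 1.9-fold lower number from compound 1 to compound 2 (0.29 log units; that floor lies within the scatter), rests on that limit and its floor sits within the scatter. Compound 3 `O=c1c(OCc2cccc(Br)c2)c(-c2ccccc2)oc2cc(O)cc(O)c12` awaits measurement in this assay. It differs from compound 1 by 3-bromophenyl in place of 2-chlorophenyl on a saturated chain carbon bound to an oxygen on an aromatic ring. Going by the values given here, no measured step exchanges one halogen for another, so no shift beyond the scatter is expected, and compound 3 is expected near the limit at 100000 nM, between 40000 nM and 250000 nM, a step of a number no higher from compound 1 to compound 3 (the limit leaves the size open).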

Compound 3, half-maximal cytotoxic concentration: 15000 nM
Compound 3: the middle estimate sits 6.7-fold (0.82 log units) above what was measured, and the stated range ends above it.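

Unlike the earlier step, this one clears the scatter, showing that the group on this saturated chain carbon can change the number in this assay: 3-bromophenyl in place of 2-chlorophenyl gives an at least 6.6-fold lower number from compound 1 to compound 3 (0.82 log units; beyond the scatter) on the shared core. Against a measured number rather than a limit, 3-bromophenyl in place of 2-nitrophenyl gives a 3.4-fold lower number from compound 2 to compound 3 (0.53 log units; beyond the scatter) and confirms that shift. The first size remains only a floor: the limit of > 100000 nM in this assay, at which 1 of the 3 values shown sits. Compound 3 changes both the halogen and its place on the ring, and the compounds shown do not tell these two apart. On these data alone, how an amine or a carboxylic acid on this ring would read stays open.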